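From methoxycarbonyl to carboxy on the shared core

This account rests on a few compounds, and the source may have more. Where it says the series, first, only, none or still open, it means among the compounds named here.

In a functional assay on PC-3 cells (Homo sapiens) for antiproliferative activity, with a stated time of 48 h (on this read-out lower numbers stand for stronger inhibition and higher numbers for weaker inhibition), compound 1 `CCN(CC)c1ccc(-c2ccc(C#N)cc2)nn1` gives > 25000 nM, which is a limit of the assay and not a number. Compound 2 `CCN(CC)c1ccc(-c2ccc(C(C)=O)cc2)nn1` gives > 25000 nM, also a limit. Among the compounds with values here, compound 3 `CCN(CC)c1ccc(-c2ccc(C(=O)OC)cc2)nn1` gives 90 nM, the only true number in the set.

Compound 4 `CCN(CC)c1ccc(-c2ccc(C(=O)O)cc2)nn1` has not yet been measured. It carries hydrogen in place of methyl on an oxygen next to a carbonyl group, which turns methoxycarbonyl into carboxy.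

Within the data shown here, no measured step makes this exact change, so the nearest evidence is indirect. Two steps end on the methoxycarbonyl group of compound 3: an at least 270-fold lower number from compound 1 to compound 3 (2.44 log units; beyond the scatter) and an at least 270-fold lower number from compound 2 to compound 3 (2.44 log units; beyond the scatter). Both are large, and the second replaces only methyl with methoxy on a carbonyl carbon. The two neighbours without methoxycarbonyl both sit at the limit of > 25000 nM in this assay, at which 2 of the 3 values shown sit. Compound 3 therefore looks like a narrow exception, and a change at the same group is expected to raise the number substantially, possibly to the limit, though a smaller rise cannot be excluded.

The expected size is a 67-fold higher number from compound 3 to compound 4 (1.82 log units; beyond the scatter), towards weaker inhibition in this assay. For compound 4 the estimated value is 6000 nM, with an expected range of 500 nM to 25000 nM.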

Compound 4, half-maximal inhibitory concentration: > 25000 nM
Compound 4 was reported as a limit; the forecaster's own chance of this, stated with the estimate: 40%; at least 4.1-fold (0.61 log units) between middle value and limit.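

In this assay, within the data shown here, the change from methoxycarbonyl to carboxy gives an at least 270-fold higher number from compound 3 to compound 4 (2.44 log units; beyond the scatter); the earlier steps replaced the whole group or the group on the carbonyl carbon, whereas this one removes only the methyl on an oxygen next to a carbonyl group. Compound 4 gives > 25000 nM, which is a limit of the assay and not a number. The loss of this one methyl is therefore enough to take compound 3 from a true number to the limit shared by compound 1, compound 2 and compound 4, leaving compound 3 as the lone exception within the set: the limit of > 25000 nM in this assay, at which 3 of the 4 values shown sit.

The steps to compound 4 from compound 1 and from compound 2 join two limits and cannot be read, so any order among these three compounds stays unknown. Also open, as far as these compounds go, is whether an ethyl ester, an isopropyl ester or a primary amide in place of methoxycarbonyl would keep a true number, or whether the effect is confined to methoxycarbonyl itself.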